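The source may report more compounds than this note shows. Statements on the series, on what has been measured and on what is new or still open speak of the compounds shown alone.

Measured compounds:
compound 1 `O=S(=O)(c1ccc(F)cc1)c1cn(C2CCNC2)c2ncccc12` — 8.5 nM
compound 2 `CN1CCC(n2cc(S(=O)(=O)c3ccccc3F)c3cccnc32)C1` — 5.6 nM
compound 3 `CN1CCC(n2cc(S(=O)(=O)c3cccc(F)c3)c3cccnc32)C1` — 1.4 nM

In an assay on HeLa cells for displacement of a labelled ligand from 5-hydroxytryptamine receptor 6 (Homo sapiens) (on this read-out lower numbers stand for stronger inhibition and higher numbers for weaker inhibition), compound 3 stands lowest of the three, and both of its distances to the others lie beyond the scatter: compound 2 gives 5.6 nM and compound 1 gives 8.5 nM. Within this set compound 3 is therefore the most potent.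

Compound 4 `CN1CCC(n2cc(S(=O)(=O)c3ccc(F)cc3)c3cccnc32)C1` is not yet measured. It differs from compound 3 in one place: 4-fluorophenyl in place of 3-fluorophenyl on a sulfonyl sulfur. Among the compounds with values here, the one measured step that bears on moving the fluorine around the phenyl ring is a 4.0-fold lower number from compound 2 to compound 3 (0.60 log units; beyond the scatter), which shows that the position of the fluorine matters by more than the scatter in this assay. Within the data shown here, no measured pair isolates the move from the 3-position to the 4-position. A 4-fluorophenyl on the sulfonyl sulfur is carried by a compound that differs from compound 4 elsewhere, so the value of compound 1, 8.5 nM, can only be read as a loose pointer, not as a step.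

On that basis compound 4 is expected to come out somewhat higher than compound 3, with the step of a 2.9-fold higher number from compound 3 to compound 4 (0.46 log units; beyond the scatter) taken as modest and uncertain in direction. The estimate for compound 4 in this assay is 4 nM, with a range from 1.5 nM to 11 nM.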

Compound 4, inhibition constant: 5 nM
Beside the measured number, compound 4's estimate is 1.3-fold (0.10 log units) below it; the measured number falls inside the stated range.
By their numbers in this assay, from the lowest: compound 3; then compounds 4, 2 and 1 (each within the scatter of the next).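

In this assay, within the data shown here, the change from 3-fluorophenyl to 4-fluorophenyl on the sulfonyl sulfur gives a 3.6-fold higher number from compound 3 to compound 4 (0.55 log units; beyond the scatter) and lies beyond the scatter, the first measured step to isolate this exchange. The 2-fluorophenyl and 4-fluorophenyl groups are not separated, with a 1.1-fold lower number from compound 2 to compound 4 (0.05 log units; within the scatter) within the scatter, so among these three fluorophenyl groups on this sulfonyl sulfur only 3-fluorophenyl stands apart. With 4-fluorophenyl held constant, methyl in place of hydrogen on the ring amine nitrogen gives a 1.7-fold lower number from compound 1 to compound 4 (0.23 log units; within the scatter), also within the scatter, so this assay does not resolve that change in this pair; no supporting data on the origin of any of these steps are available.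

From the compounds shown here alone, whether the standing of 3-fluorophenyl is specific to fluorine remains open, since a 3-chlorophenyl, a 3-methoxyphenyl or an unsubstituted phenyl on the sulfonyl sulfur would be needed to test it. Also open, going by these compounds, is whether the methyl and hydrogen forms of the ring amine nitrogen would stay unresolved with 3-fluorophenyl in place, and how an ethyl group on that nitrogen would read.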